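From compound 3 to its 4-hydroxyphenyl counterpart

A few compounds are considered here, and "the series" means these few. Any claim that something is new, unique, unknown or untested is made for them only; others in the source may bear on it.

Of the compounds shown here, three sharing one core have been measured so far. Compound 1 `O=C(Nc1ccc2[nH]ccc2n1)[C@H]1CCCN1C(=O)C1(c2cccc(Cl)c2)CCCC1` reads 5.9 in a physicochemical assay for lipophilicity, at pH 7.4 (a lower number here means a more polar compound, a higher number a more lipophilic compound), and compound 2 `O=C(Nc1ccc2[nH]c(=O)[nH]c2c1)[C@H]1CCCN1C(=O)C1(c2cccc(Cl)c2)CCCC1` reads 4.4 on the same scale, while compound 3 `O=C(Nc1ccc2[nH]nnc2c1)[C@H]1CCCN1C(=O)C1(c2cccc(Cl)c2)CCCC1` reads 5.2 and so holds the middle place of the three numbers.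

Compound 4 `O=C(Nc1ccc(O)cc1)[C@H]1CCCN1C(=O)C1(c2cccc(Cl)c2)CCCC1` is still unmeasured. It departs from compound 3 by a group of 7 heavy atoms (6 carbon, 1 oxygen; one six-membered aromatic ring of carbon only) in place of a group of 9 heavy atoms (6 carbon, 3 nitrogen; one five-membered aromatic ring with 3 hetero atoms, one six-membered aromatic ring of carbon only), on an amide-type nitrogen at a single place, and the entering group is 4-hydroxyphenyl.

Among the compounds with values here, three measured steps touch that same place: a number 1.50 log units lower from compound 1 to compound 2 (beyond the scatter) is large, while a number 0.70 log units lower from compound 1 to compound 3 (beyond the scatter) and a number 0.80 log units higher from compound 2 to compound 3 (beyond the scatter) are modest, and all three lie beyond the scatter. They show that changes on this nitrogen have moved the number in both directions, but none of them brings in 4-hydroxyphenyl. Within the data shown here, of the groups measured, only the one in compound 2 at 4.4 holds an oxygen, as 4-hydroxyphenyl does, so a modest fall rather than a rise is expected in this assay for this change. The estimated step is a number 0.40 log units lower from compound 3 to compound 4 (beyond the scatter) and it is expected to be modest. For compound 4 the estimated value is 4.8 within an expected range of 4.2 to 5.4 once it is measured.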

Compound 4, distribution coefficient: 5.5
The estimate for compound 4 lay 0.70 log units below the measured number, and the stated range ends below it.
By their numbers in this assay, from the lowest: compound 2; then compounds 3 and 4 (each within the scatter of the next); then compound 1.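

In this assay the 4-hydroxyphenyl group on the amide-type nitrogen, with one six-membered aromatic ring of carbon only, cannot be told apart from the group of compound 3, which also carries a five-membered aromatic ring with 3 hetero atoms (a number 0.30 log units higher from compound 3 to compound 4 (within the scatter)). The oxygen shared with the group of compound 2 did not bring these two compounds together, for the step between them is large (a number 1.10 log units higher from compound 2 to compound 4 (beyond the scatter)), so holding an oxygen does not by itself place a group with compound 2 on this scale. The step to compound 4 from compound 1 is modest but beyond the scatter (a number 0.40 log units lower from compound 1 to compound 4 (beyond the scatter)), which leaves compound 4 grouped with compound 3, clear of both compound 1 and compound 2.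

The compounds shown leave open how plain phenyl, 4-methoxyphenyl or 4-aminophenyl on this nitrogen would read against 4-hydroxyphenyl, and so what the hydroxyl itself contributes to the number. Nothing at hand bears on why these groups fall where they do.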